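This account rests on a few compounds, and the source may have more. Where it says the series, first, only, none or still open, it means among the compounds named here.

Of the compounds shown here, three have so far been tested in a functional assay on the whole organism with Rattus norvegicus as the target; a lower number here means that less compound is needed, a higher number that more compound is needed for the effect. Compound 1 `CCCCCCCc1ccc2nc(N)sc2c1` is reported only as a limit, > 10 mg/kg. In this assay compound 2 `CCn1c(=N)sc2cc(OC(F)(F)F)ccc21` gives 5 mg/kg, and compound 3 `CCCCn1c(=N)sc2cc(OC(F)(F)F)ccc21` gives 10 mg/kg. Among the compounds with values here, compound 3 therefore stands within the scatter of compound 2, its only neighbour with a plain number, and the two cannot be told apart.

The next compound, compound 4 `N#CCn1c(=N)sc2cc(OC(F)(F)F)ccc21`, keeps the core of compound 3 and alters only the chain: cyano in place of propyl on a saturated chain carbon bound to an aromatic nitrogen. This is cyano in place of propyl on a saturated chain carbon bound to an aromatic nitrogen, which, cut one bond further out, reads butyl to cyanomethyl.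

Within the data shown here, one measured step bears on this chain: a 2.0-fold higher number from compound 2 to compound 3 (0.30 log units; within the scatter). Among the measured compounds shown here, it involves only plain alkyl chains, and no tested compound carries a cyano group, so it is a weak guide to the new change. Resting on that single small step, the estimated step is a 1.4-fold lower number from compound 3 to compound 4 (0.15 log units; within the scatter), and no shift beyond the scatter is expected in this assay, in either direction. For compound 4 the expected value is 7 mg/kg, with an estimated range from 2.5 mg/kg to 20 mg/kg.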

Compound 4, dose for half-maximal effect: 3.5 mg/kg
Estimate against measurement, compound 4: 2.0-fold (0.30 log units) above; the range from low to high includes it.
By their numbers in this assay, from the lowest: compounds 4, 2 and 3 (each within the scatter of the next, the first and the last beyond it).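

In this assay, within the data shown here, the change from butyl to cyanomethyl is the first change on this chain to go beyond the scatter: a 2.9-fold lower number from compound 3 to compound 4 (0.46 log units; beyond the scatter). The earlier step between the two plain alkyl chains did not separate its compounds, whereas this one shows that the result at a saturated chain carbon bound to an aromatic nitrogen can shift measurably with the group placed there. The separation holds only against compound 3, however, as the other new step, a 1.4-fold lower number from compound 2 to compound 4 (0.15 log units; within the scatter), leaves compound 4 indistinguishable from compound 2, and nothing given here accounts for the shift.

The compounds shown leave open whether the nitrile itself matters or whether a shorter chain alone would give the same result, as compound 2 and compound 4 cannot be told apart. A propyl chain, a longer chain ending in a nitrile, or an amine or a carboxylic acid at the end of the chain would each test this further.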